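Fluoro for methyl on the anilino ring of compound 3

The compounds below may be only part of what the source reports. "The series", "measured", "known", "first", "only" and "open" are said of these compounds alone.

Measured so far in a functional assay for inhibition, with Homo sapiens as the target; a lower number here means a stronger inhibitor, a higher number a weaker inhibitor:
compound 1 `Fc1cccc(Nc2nccc(-c3ccccn3)n2)c1` gives 1000 nM
compound 2 `Cc1cccc(Nc2nccc(-c3ccco3)n2)c1` gives 2100 nM
compound 3 `Cc1cccc(Nc2nccc(-c3ccncc3)n2)c1` gives 8800 nM

Compound 3 stands at the highest number of the three; compound 2 sits nearest, compound 1 furthest. Among the compounds with values here, the one step among them, a 4.2-fold higher number from compound 2 to compound 3 (0.62 log units; beyond the scatter), concerns the heteroaryl group and not the anilino ring, so it does not bear on the present change.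

Compound 4 `Fc1cccc(Nc2nccc(-c3ccncc3)n2)c1` differs from compound 3 by fluoro in place of methyl on an aromatic carbon. Within the data shown here, compound 1 carries the same fluoro but a different heteroaryl group, so only its value and that of compound 3 are known, and no single-point step isolates fluoro against methyl. The expectation is therefore a step of a 1.3-fold lower number from compound 3 to compound 4 (0.10 log units; within the scatter) in this assay, a change within the scatter.

In this assay compound 4 is expected at 7000 nM, within 2500 nM to 20000 nM.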

Compound 4, half-maximal inhibitory concentration: 700 nM
Compound 4: middle estimate off by 10-fold (1.00 log units), on the high side; the measured number lies below the stated range.
By their numbers in this assay, from the lowest: compounds 4 and 1 (each within the scatter of the next); then compound 2; then compound 3.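

In this assay, within the data shown here, this position proves sensitive: with pyridin-4-yl held, fluoro in place of methyl gives a 13-fold lower number from compound 3 to compound 4 (1.10 log units; beyond the scatter) and is the largest single change so far. With fluoro held, pyridin-4-yl in place of pyridin-2-yl gives a 1.4-fold lower number from compound 1 to compound 4 (0.15 log units; within the scatter) and so leaves the two fluoro compounds level. Nothing measured on these compounds accounts for the fluoro step.

Going by these compounds, whether fluoro in place of methyl gives a step of like size with furan-2-yl remains open. So does how chloro, methoxy or an amine would compare on this aromatic carbon.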